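The source may hold more compounds than are shown below. What is called first, only, known or untested is meant among the compounds shown, and "the series" means these compounds.

Measured so far, in an assay on CHO cells for displacement of a labelled ligand from Alpha-2C adrenergic receptor (Homo sapiens); on this read-out lower numbers stand for stronger inhibition and higher numbers for weaker inhibition:
- Compound 1, `CC(Oc1ccccc1-c1ccncc1)C1=NCCN1`, gives 1450 nM
- Compound 2, `CC(Oc1ccccc1-c1ccccc1)C1=NCCO1`, gives 5890 nM

Compound 1 stands lowest of the two numbers, and the gap from compound 1 up to compound 2 lies beyond the usual scatter of repeated measurements. Going by the values given here, compound 2 differs from compound 1 in more than one place, so its value shows only that both changes together gave a weaker compound.

The next compound, compound 3, `CC(Oc1ccccc1-c1ccccn1)C1=NCCN1`, keeps every atom of compound 1 but joins them differently: pyridin-2-yl in place of pyridin-4-yl on an aromatic carbon. Among the compounds with values here, no pair of measured compounds shows this change on its own, so nothing here tells its size directly. With only the two values at hand, the expectation is a step of modest size, if any, most likely toward a somewhat higher number or none beyond the scatter.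

In this assay compound 3 is therefore expected to give about 2200 nM, within a range from 700 nM to 7000 nM, which would mean a step of a 1.5-fold higher number from compound 1 to compound 3 (0.18 log units; within the scatter).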

Compound 3, inhibition constant: 1260 nM
Compound 3: the middle estimate sits 1.7-fold (0.24 log units) above what was measured, within the range that was stated.
By their numbers in this assay, from the lowest: compounds 3 and 1 (each within the scatter of the next); then compound 2.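

Within this assay the exchange of pyridin-4-yl for pyridin-2-yl on this aromatic carbon gives a 1.2-fold lower number from compound 1 to compound 3 (0.06 log units; within the scatter) and so leaves the two compounds indistinguishable. Going by these compounds alone, this is the first direct reading of this change: at this place, ortho to a group of 8 heavy atoms, the two pyridine attachments give matching results. No measurement shown here offers an explanation for this outcome.

Going by these compounds, what pyridin-3-yl or a pyridine ring carrying an amine would give at this place remains open. The separate effect of replacing the pyridine ring with phenyl is also unresolved, as compound 2 differs from compound 1 in more than one place.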